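Working notes on a small antiproliferative series

This account rests on a few compounds, and the source may have more. Where it says the series, first, only, none or still open, it means among the compounds named here.

Compound 1 `COc1ccc(/C=C/C(=O)c2ccc(OC)c3c2OC(C)(C)C=C3)c(F)c1` has so far been tested only in a functional assay on HCT-116 cells (Homo sapiens) for antiproliferative activity, read by MTT assay, with a stated time of 24 h; a higher number here means a weaker inhibitor, a lower number a stronger inhibitor. In this assay compound 1 returns > 10000 nM, which is a limit of the assay rather than a number. For the measured compounds named here, the only other measured member, compound 2 `COc1ccc(C(=O)/C=C/c2ccc3ccccc3n2)c2c1C=CC(C)(C)O2`, gives 4530 nM in this assay. Going by the values given here, compound 1 thus stands at the limit of > 10000 nM in this assay, at which 1 of the 2 values shown sits, and no measured step between close neighbours exists. Compound 3 `COc1ccccc1/C=C/C(=O)c1ccc(OC)c2c1OC(C)(C)C=C2` has not yet been measured; it differs from compound 1 by 2-methoxyphenyl in place of 2-fluoro-4-methoxyphenyl on a double-bonded chain carbon bound to a double-bonded chain carbon. Among the compounds with values here, with compound 1 sitting at a limit and no comparable step on record, neither the size nor the direction of this change can be read from the data. The expected step is a step that the limit leaves unreadable from compound 1 to compound 3, nothing beyond the scatter. Compound 3 is accordingly estimated at 15000 nM in this assay, within 4000 nM to 50000 nM, with a real chance that only a limit is reported again.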

Compound 3, half-maximal inhibitory concentration: > 10000 nM
Compound 3: a limit, no number (the forecaster's own chance of this, stated with the estimate: 60%); the middle value does not contradict the limit.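

No step from compound 1 to compound 3 can be read in this assay, because each compound returns only a limit of the assay and not a number: the limit of > 10000 nM in this assay, at which 2 of the 3 values shown sit.

The compounds shown leave open whether 2-methoxyphenyl and 2-fluoro-4-methoxyphenyl differ at all in this read-out.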